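The source may report more compounds than this note shows. Statements on the series, on what has been measured and on what is new or still open speak of the compounds shown alone.

Measured compounds:
compound 1, `O=C(Nc1ccc(Cl)c(-c2nnc3c(Cl)cccn23)c1)c1cccc(Cl)c1`: 54800 nM
compound 2, `O=C(Nc1ccc(Cl)c(-c2nnc3c(Cl)cccn23)c1)c1ccc(Cl)cc1`: > 100000 nM
compound 3, `CS(=O)(=O)c1cccc(C(=O)Nc2ccc(Cl)c(-c3nnc4c(Cl)cccn34)c2)c1`: > 100000 nM

Among the measured compounds shown here, in a functional assay on MDA-MB-468 cells (Homo sapiens) for antiproliferative activity, read by MTT assay, with a stated time of 72 h (on this read-out lower numbers stand for stronger inhibition and higher numbers for weaker inhibition), compound 1 gives 54800 nM, the only number among the three values shown. For compound 2 the value > 100000 nM is a limit of the assay, not a number. For compound 3 the value > 100000 nM is likewise a limit. Compound 4, `CS(=O)(=O)c1ccc(C(=O)Nc2ccc(Cl)c(-c3nnc4c(Cl)cccn34)c2)cc1`, is not yet measured; it differs from compound 1 by 4-(methylsulfonyl)phenyl in place of 3-chlorophenyl on a carbonyl carbon. For the measured compounds named here, two measured steps bear on this change: an at least 1.8-fold higher number from compound 1 to compound 2 (0.26 log units; that floor lies within the scatter), and an at least 1.8-fold higher number from compound 1 to compound 3 (0.26 log units; that floor lies within the scatter); the step that the two limits leave unreadable from compound 2 to compound 3 gives no size. Both readable steps run to higher numbers and end at the limit of > 100000 nM in this assay, at which 2 of the 3 values shown sit. Compound 4 combines both changes, so compound 4 is expected to show a step of a 2.7-fold higher number from compound 1 to compound 4 (0.44 log units; beyond the scatter), most likely again a limit. Compound 4 is therefore estimated at 150000 nM, within 60000 nM to 400000 nM.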

Compound 4, half-maximal inhibitory concentration: > 100000 nM
Compound 4: a limit, no number (the forecaster's own chance of this, stated with the estimate: 75%); the middle value lies beyond the limit too.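

In this assay compound 4 gives > 100000 nM, which is a limit of the assay, so 4-(methylsulfonyl)phenyl on the carbonyl carbon yields no number either. The change gives an at least 1.8-fold higher number from compound 1 to compound 4 (0.26 log units; that floor lies within the scatter), so compound 1 still cannot be separated from compound 4 by more than the scatter. The steps among compound 2, compound 3 and compound 4 cannot be read, and compound 1 remains the only number in the set: the limit of > 100000 nM in this assay, at which 3 of the 4 values shown sit.

As far as these compounds go, how far compound 2, compound 3 and compound 4 lie past that limit stays open. So does whether an amine or a carboxylic acid on this phenyl ring would give a readable value.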